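Swapping 3,4-dichlorophenyl for 3,4-difluorophenyl on the carbonyl

This account rests on a few compounds, and the source may have more. Where it says the series, first, only, none or still open, it means among the compounds named here.

Compound 1 `COc1cc(-c2cc(/C=C/C(=O)c3ccc(Cl)c(Cl)c3)[nH]n2)cc(OC)c1OC` is tested in a functional assay on NCI/ADR-RES cells (Homo sapiens) for inhibition, read by sulforhodamine B assay, with a stated time of 48 h (a lower number here means that less compound is tolerated, a higher number that more compound is tolerated), and returns only a limit, > 100000 nM, which is not a number. Compound 2 `COc1ccc(-c2cc(/C=C/C(=O)c3ccc(N)cc3)[nH]n2)cc1OC` likewise returns only a limit in this assay, > 100000 nM. Where compound 1 stands is therefore plain: the limit of > 100000 nM in this assay, at which 2 of the 2 values shown sit, and compound 1 is not separated from compound 2 on this read-out. Compound 3 `COc1cc(-c2cc(/C=C/C(=O)c3ccc(F)c(F)c3)[nH]n2)cc(OC)c1OC` has not yet been measured in this assay. It differs from compound 1 in one place: 3,4-difluorophenyl in place of 3,4-dichlorophenyl on a carbonyl carbon. Within the data shown here, no step between two measured compounds that differ in one place is available in this assay, so the size of the effect of this change cannot be read from the data. Compound 3 is expected to behave like compound 1, with the step of a number no higher from compound 1 to compound 3 (the limit leaves the size open) expected to be none beyond the scatter. For compound 3 the estimate is 100000 nM, with a range of 30000 nM to 300000 nM, and most likely again only a limit.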

Compound 3, concentration lethal to 50% of the cells: > 100000 nM
Compound 3 gave a limit, no number; the forecaster's own chance of this, stated with the estimate: 80%; the middle value sits exactly at the limit.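

Compound 1 and compound 3 both return only a limit in this assay, so the step from 3,4-dichlorophenyl to 3,4-difluorophenyl on the carbonyl carbon cannot be read: the limit of > 100000 nM in this assay, at which 3 of the 3 values shown sit.

The compounds shown leave open which change on the shared core, if any, would give a number in this assay.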